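A few compounds are considered here, and "the series" means these few. Any claim that something is new, unique, unknown or untested is made for them only; others in the source may bear on it.

Working notes on the series. In an assay on MDA-MB-231 cells for binding affinity to C-X-C chemokine receptor type 4 (Homo sapiens), read by immunofluorescence and microscopy, with stated times of 10 min and 30 min (on this read-out lower numbers stand for an effect already at smaller amounts and higher numbers for an effect only at larger amounts of compound), compound 1 `Cc1ccc(S(=O)(=O)NCc2ccc(CNC(=O)c3ccccc3)cc2)cc1` gives only the limit > 1000 nM; this is the limit of the read-out and not a number (the limit of > 1000 nM in this assay, at which 1 of the 3 values shown sits). Among the measured compounds shown here, compound 2 `Cc1ccc(S(=O)(=O)NCc2ccc(CNC(=O)c3ccc([N+](=O)[O-])cc3)cc2)cc1` gives 10 nM in this assay, and the step of an at least 100-fold lower number from compound 1 to compound 2 (2.00 log units; beyond the scatter) is the one measured change, nitro in place of hydrogen on an aromatic carbon. Compound 3 `O=C(NCc1ccc(CNS(=O)(=O)c2ccccc2)cc1)c1ccc(F)cc1` gives 100 nM in this assay; this is the higher of the two numbers shown, with compound 2 the nearer of the other compounds and the lower number of the two, the gap between them lying beyond the scatter.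

Compound 4 `Cc1cccc(C(=O)NCc2ccc(CNS(=O)(=O)c3ccccc3)cc2)c1` is not yet measured. It differs from compound 3 by 3-methylphenyl in place of 4-fluorophenyl on a carbonyl carbon. For the measured compounds named here, no measured step touches this change: the only step known alters the group on an aromatic carbon of the same ring, while here the whole ring on the carbonyl carbon is exchanged, and compound 1 and compound 3 differ in two places at once, so their values give no single step. Going by the values given here, with no step that bears on it, no change beyond the scatter is expected, and compound 4 is estimated to stand at 150 nM in this assay, between 40 nM and 600 nM, with the expected step being a 1.5-fold higher number from compound 3 to compound 4 (0.18 log units; within the scatter).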

Compound 4, effective concentration (reported as EC, without a stated level of effect): 1000 nM
For compound 4 the middle estimate is 6.7-fold (0.82 log units) below the measured one, and the stated range ends below it.
By their numbers in this assay, from the lowest: compound 2; then compound 3; then compound 4.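

In this assay, among the compounds shown here, a 10-fold higher number from compound 3 to compound 4 (1.00 log units; beyond the scatter) is the first measured step in which the ring on the carbonyl carbon is exchanged as a whole, rather than gaining a group in place of hydrogen. The 4-fluorophenyl and 3-methylphenyl groups have the same count of heavy atoms and neither has hydrogen-bond donors or acceptors, so these counts do not follow the change in the number at this position. Compound 1 remains the only compound in the series at a limit, which is a limit of the read-out and not a number: the limit of > 1000 nM in this assay, at which 1 of the 4 values shown sits.

The step changes the group on the ring and its place together, so a pair such as 3-fluorophenyl and 4-methylphenyl would be needed to separate the two changes. From the compounds shown here alone, whether an amine or a carboxylic acid on this ring would go with the nitro group of compound 2 or with the methyl group of compound 4 stays open, and the step to nitro is known only on the core of compound 1.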